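Three compounds at the limit, and one untested cousin

The source may report more compounds than this note shows. Statements on the series, on what has been measured and on what is new or still open speak of the compounds shown alone.

The series is measured in an ADME assay on BaF3 cells (Mus musculus) for antiproliferative activity, read by CellTiter-Glo and CCK-8 assay, with a stated time of 72 h; on this read-out higher numbers stand for weaker inhibition of growth and lower numbers for stronger inhibition of growth. Compound 1 `Cc1ccc(NC(=O)c2cccc(C(F)(F)F)c2)cc1N1Cc2cnc(Nc3ccc(C)c(C(F)(F)F)c3)nc2N(C)C1=O` gives > 10000 nM, which is a limit of the assay rather than a number. Compound 2 `CNc1nc(Nc2ccc(C)c([N+](=O)[O-])c2)ncc1C(=O)Nc1cc(NC(=O)c2ccccc2OC)ccc1C` likewise gives > 10000 nM, again a limit. Compound 3 `CNc1nc(Nc2ccc(C)c(N)c2)ncc1C(=O)Nc1cc(NC(=O)c2ccccc2OC)ccc1C` gives > 10000 nM, also a limit. Compound 2 and compound 3 differ only in an amino in place of a nitro on an aromatic carbon, and the step that the two limits leave unreadable from compound 2 to compound 3 cannot be read because both ends are limits. So far every value sits at the same point, as noted in the limit of > 10000 nM in this assay, at which 3 of the 3 values shown sit, and no measured step gives a readable size at all.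

Compound 4 `CNc1nc(Nc2ccc(C)c(N)c2)ncc1C(=O)Nc1cc(NC(=O)c2cc(OC)cc(OC)c2)ccc1C` has not been measured. It differs from compound 3 in one place: 3,5-dimethoxyphenyl in place of 2-methoxyphenyl on a carbonyl carbon. For the measured compounds named here, no measured step touches this part of the molecule, so nothing in the data points in either direction. Going by the values given here, the only guide is that compound 3 sits at the limit, and a single change of this kind gives no reason to expect a readable number. Compound 4 is therefore expected to remain near the limit, with an estimated value of 10000 nM in a range from 3000 nM to 30000 nM. The expected step of a number no higher from compound 3 to compound 4 (the limit leaves the size open) is, in effect, none beyond the scatter.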

Compound 4, concentration for 50% growth inhibition: > 10000 nM
Compound 4 ended at the assay's limit (the forecaster's own chance of this, stated with the estimate: 75%); the middle value sits exactly at the limit.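

Compound 3 and compound 4 both stand at a limit rather than a number, so no step can be read for 3,5-dimethoxyphenyl in place of 2-methoxyphenyl: the limit of > 10000 nM in this assay, at which 4 of the 4 values shown sit.

The compounds shown leave open how far each lies beyond that limit, and which change to these structures, if any, would give a readable number in this assay.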